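The compounds below may be only part of what the source reports. "The series", "measured", "known", "first", "only" and "open" are said of these compounds alone.

Measured so far:
- compound 1, `Cc1cc(C)c2c(C#N)cn(-c3ccc(C(C)C)cc3Br)c2n1`, gives 363 nM in an assay on isolated protein for binding affinity to corticotropin-releasing factor receptor 1 (Rattus norvegicus); on this read-out lower numbers stand for stronger inhibition and higher numbers for weaker inhibition
- compound 2, `Cc1cc(-c2ccccc2)c2ccn(-c3ccc(C(C)C)cc3Br)c2n1`, gives 36 nM in this assay

Of these two numbers, compound 2 holds the lower one, and the gap to compound 1 lies beyond the usual scatter of repeated measurements. The two structures differ in more than one place, so no single change can be read from that gap on its own.

Compound 3, `Cc1cc(Cl)c2ccn(-c3ccc(C(C)C)cc3Br)c2n1`, has not yet been measured. It differs from compound 2 in exactly one place: chloro in place of phenyl on an aromatic carbon. Among the compounds with values here, no measured pair shows this particular exchange, so its effect is open. A single chlorine now stands where a whole ring stood before, and a noticeable shift in the number in this assay is possible in either direction. The expectation is that compound 3 gives a somewhat higher number than compound 2, a step of a 2.8-fold higher number from compound 2 to compound 3 (0.44 log units; beyond the scatter) that may reach just beyond the scatter. The estimate for compound 3 in this assay is 100 nM, with a range from 30 nM to 400 nM.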

Compound 3, inhibition constant: 67 nM
For compound 3 the middle estimate is 1.5-fold (0.17 log units) above the measured one, within the range that was stated.
By their numbers in this assay, from the lowest: compounds 2 and 3 (each within the scatter of the next); then compound 1.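

In this assay, placing chloro in place of phenyl on this aromatic carbon, opposite the ring nitrogen, gives a 1.9-fold higher number from compound 2 to compound 3 (0.27 log units; within the scatter), so the two compounds cannot be told apart in this measurement. For this pair, then, a single chlorine atom can stand where a whole six-membered aromatic ring stood without a change that rises above the scatter, which means the phenyl ring is not needed at this position to reach a number of this size. Nothing shown here explains why two such different groups read alike.

Within the data shown here, how an amine, a carboxylic acid or a longer chain on this same carbon would read remains open, since the single step covers only phenyl and chloro. Compound 1 carries a methyl group on this carbon, but it also has a nitrile elsewhere on the core, so its number cannot show what the methyl group alone does and leaves the role of the group at this position only partly mapped.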